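The source may report more compounds than this note shows. Statements on the series, on what has been measured and on what is new or still open speak of the compounds shown alone.

For the measured compounds named here, in a functional assay on HeLa cells (Homo sapiens) for antiproliferative activity, read by cell counting, with a stated time of 2 days (on this read-out lower numbers stand for stronger inhibition and higher numbers for weaker inhibition), compound 3 `COc1ccccc1C(=O)c1sc(Nc2ccccc2)nc1N` gives 1200 nM, the highest number so far, against compound 1 `COc1ccc(Nc2nc(N)c(C(=O)c3ccccc3)s2)cc1` at 230 nM and compound 2 `COc1ccc(Nc2nc(N)c(C(=O)c3ccc(Br)cc3)s2)cc1` at 79 nM. Compound 4 `COc1ccc(Nc2nc(N)c(C(=O)c3ccccc3OC)s2)cc1` differs from compound 3 by methoxy in place of hydrogen on an aromatic carbon, para to a large group: methoxy in place of hydrogen on an aromatic carbon. Going by the values given here, the only measured single-place step is a 2.9-fold lower number from compound 1 to compound 2 (0.46 log units; beyond the scatter), a modest change from bromo at another place in the structure, so it bears only indirectly. Among the compounds with values here, compound 1 and compound 2 both carry the 4-methoxyphenyl group that compound 4 gains, and both lie lower than compound 3, though no measured step isolates that group. A modest to moderate drop in the number is therefore expected. The expected change is a 3.0-fold lower number from compound 3 to compound 4 (0.48 log units; beyond the scatter). For compound 4 the estimate is 400 nM, with an expected range of 100 nM to 1500 nM.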

Compound 4, half-maximal inhibitory concentration: 17 nM
Compound 4: the middle estimate sits 24-fold (1.37 log units) above what was measured; measured number outside the range, below it.
By their numbers in this assay, from the lowest: compound 4; then compound 2; then compound 1; then compound 3.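

Within this assay the change from phenyl to 4-methoxyphenyl is the largest single-place step in the series (a 71-fold lower number from compound 3 to compound 4 (1.85 log units; beyond the scatter)), so this position on the aromatic ring strongly affects the read-out. A methoxy added on the other aromatic ring also gives a large step (a 14-fold lower number from compound 1 to compound 4 (1.13 log units; beyond the scatter)), and 2-methoxyphenyl in place of 4-bromophenyl on the carbonyl carbon gives a modest one (a 4.6-fold lower number from compound 2 to compound 4 (0.67 log units; beyond the scatter)). Nothing measured here explains these steps.

Still open, as far as these compounds go, is whether a hydroxy, an ethoxy or an amine at the 4-methoxyphenyl position would match methoxy. The same question holds for these groups in place of the methoxy of the 2-methoxyphenyl group.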